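Reversing the amide on the cyclohexyl ring of compound 3

The compounds below may be only part of what the source reports. "The series", "measured", "known", "first", "only" and "open" are said of these compounds alone.

Measured so far in an assay for inhibition of Indoleamine 2,3-dioxygenase 1 (Homo sapiens), with a stated time of 1 h; a higher number here means a weaker inhibitor, a lower number a stronger inhibitor:
- compound 1 `O=C(/C(=N/O)Nc1ccc(F)c(Br)c1)C1CCN(C(=O)NCc2ccccc2)CC1` — 43 nM
- compound 2 `O=C(/C(=N/O)Nc1ccc(F)c(Br)c1)C1CCCCC1` — 132 nM
- compound 3 `O=C(Nc1ccccc1)[C@H]1CC[C@H](C(=O)/C(=N/O)Nc2ccc(F)c(Br)c2)CC1` — 150 nM

Compound 3 returns the highest of the three numbers, though its gap to compound 2 is within the scatter; only compound 1 stands clearly apart, with a lower number. Among the measured compounds shown here, the one measured step that reaches compound 3 is a 1.1-fold higher number from compound 2 to compound 3 (0.06 log units; within the scatter), so attaching a phenylcarbamoyl group to the saturated ring carbon left the value essentially where compound 2 had it.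

Compound 4 `O=C(NC[C@H]1CC[C@H](C(=O)/C(=N/O)Nc2ccc(F)c(Br)c2)CC1)c1ccccc1` differs from compound 3 in one place: benzamidomethyl in place of phenylcarbamoyl on a saturated ring carbon. For the measured compounds named here, no measured step covers this particular exchange. Going by the values given here, the only bearing step, from compound 2 to compound 3, was flat, and compound 1, which carries a benzyl group on a nitrogen of its urea, shows a lower number than compound 3 without a step connecting them. Compound 4 is therefore expected to land near compound 3 or somewhat lower, a step of a 1.5-fold lower number from compound 3 to compound 4 (0.18 log units; within the scatter) in this assay. The estimate for compound 4 is 100 nM, within 40 nM to 250 nM.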

Compound 4, half-maximal inhibitory concentration: 80 nM
Beside the measured number, compound 4's estimate is 1.3-fold (0.10 log units) above it, and the stated range covers the measured number.
By their numbers in this assay, from the lowest: compounds 1, 4, 2 and 3 (each within the scatter of the next, the first and the last beyond it).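

In this assay the exchange of phenylcarbamoyl for benzamidomethyl gives a 1.9-fold lower number from compound 3 to compound 4 (0.27 log units; within the scatter) and so stays within the scatter, which shows that a second large group on this saturated ring carbon, with one more heavy atom and the same counted hydrogen-bond donor and acceptor, does not separate clearly from the first. Against the ring without any such group, the change gives a 1.7-fold lower number from compound 2 to compound 4 (0.22 log units; within the scatter) and also stays within the scatter, so neither group has yet moved the number clearly away from compound 2. No measurement shown accounts for these small steps.

The compounds shown leave open whether a carboxylic acid or an amine in this place, or a longer chain carrying the benzamide, would move the number beyond the scatter. They also leave open whether a methoxy group or a fluorine on the aromatic ring of benzamidomethyl would do so.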